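The source may report more compounds than this note shows. Statements on the series, on what has been measured and on what is new or still open speak of the compounds shown alone.

Three thiosemicarbazide-type compounds sharing one core were tested in a functional assay on A-431 cells (Homo sapiens) for cytotoxicity, read by MTT assay, with a stated time of 72 h, tested at 3 uM; a higher number here means more inhibition of growth at the concentration tested, a lower number less inhibition of growth. Compound 1 `Cc1ccnc(/C(N)=N/NC(=S)N2CCSCC2)c1` gives 34.7% in this assay. Compound 2 `Cc1ccnc(/C(N)=N/NC(=S)N2CCCCCC2)c1` gives 36.1%, and compound 3 `Cc1cccc(/C(N)=N/NC(=S)N2CCCC2)n1` gives 47.2%. Of these three numbers, compound 1 has the lowest, yet the number of compound 2 lies within the usual scatter of it, so the two cannot be told apart; only compound 3 sits beyond the scatter above compound 1.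

Compound 4 `Cc1ccnc(/C(N)=N/NC(=S)N2CCOCC2)c1` has not yet been measured. It differs from compound 1 in one place: morpholin-4-yl in place of thiomorpholin-4-yl on a thiocarbonyl carbon. Among the measured compounds shown here, no measured pair shows how swapping one six-membered ring with two hetero atoms for another of this kind changes the reading, so the closest guide is the small spread between compound 1 and compound 2, whose different rings sit on the same thiocarbonyl carbon. In this assay the expected step of a number 0.3 percentage points higher from compound 1 to compound 4 (within the scatter) is small, with no direction beyond the scatter. Compound 4 is therefore estimated at 35%, with a range from 20% to 50%.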

Compound 4, percent growth inhibition at one concentration: 35.5%
Compound 4: middle estimate off by 0.5 percentage points, on the low side; the measured number falls inside the stated range.
By their numbers in this assay, from the lowest: compounds 1, 4 and 2 (each within the scatter of the next); then compound 3.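

In this assay, among the compounds shown here, morpholin-4-yl in place of thiomorpholin-4-yl on a thiocarbonyl carbon gives a number 0.8 percentage points higher from compound 1 to compound 4 (within the scatter), the first measured step in which only one group is exchanged. Both groups are six-membered non-aromatic rings with 2 hetero atoms, and exchanging the ring sulfur for a ring oxygen leaves two readings that cannot be told apart at this position. Nothing available here explains this result.

The compounds shown leave open whether a quite different group on the same thiocarbonyl carbon, such as an open-chain dimethylamino group or a piperazin-1-yl ring, would shift the reading beyond the scatter. They also leave open what lies behind the higher number of compound 3, which differs from compound 1 in more than one place.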